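Removing a Benzyl Group on a Rearranged Core

A few compounds are considered here, and "the series" means these few. Any claim that something is new, unique, unknown or untested is made for them only; others in the source may bear on it.

In a functional assay on HepG2 cells (Homo sapiens) for cytotoxicity, read by spectrophotometry, with a stated time of 72 h (a lower number here means a stronger inhibitor, a higher number a weaker inhibitor), compound 1 `COc1ccc(-c2cccc(=O)n2-c2cc(OC)c(OC)c(OC)c2)cc1OCc1ccccc1` gives 269 nM. In this assay compound 3 `COc1ccc(-n2c(-c3cc(OC)c(OC)c(OC)c3)cccc2=O)cc1OCc1ccccc1` gives 3040 nM. Compound 2 `COc1ccc(-c2cccc(=O)n2-c2cc(OC)c(OC)c(OC)c2)cc1O` reaches only a limit of the assay, < 10 nM, which is the limit of < 10 nM in this assay, at which 1 of the 3 values shown sits.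

Compound 1 and compound 3 are built from the same atoms joined differently; the difference between the two cores is not broken down here. Compound 2 differs from compound 1 by hydrogen in place of benzyl on an oxygen on an aromatic ring, and this change gave an at least 26-fold lower number from compound 1 to compound 2 (1.42 log units; beyond the scatter). Compound 4 `COc1ccc(-n2c(-c3cc(OC)c(OC)c(OC)c3)cccc2=O)cc1O` differs from compound 3 by hydrogen in place of benzyl on an oxygen on an aromatic ring, the same change at the same kind of place. A step of similar size is expected, a 28-fold lower number from compound 3 to compound 4 (1.44 log units; beyond the scatter), because the same change produced an at least 26-fold lower number from compound 1 to compound 2 (1.42 log units; beyond the scatter). Compound 4 is therefore estimated to give 110 nM in this assay, most likely between 15 nM and 600 nM.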

Compound 4, half-maximal inhibitory concentration: 1220 nM
For compound 4 the middle estimate is 11-fold (1.04 log units) below the measured one; the measured number lies above the stated range.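

On the core of compound 3, the change from benzyloxy to hydroxy still lowers the number in this assay, with a 2.5-fold lower number from compound 3 to compound 4 (0.40 log units; beyond the scatter). The direction of the change carries over from one core to the other, but its size does not, and these two pairs do not show why: the same change on two cores in this assay, an at least 26-fold lower number (1.42 log units; beyond the scatter) from compound 1 to compound 2 and a 2.5-fold lower number (0.40 log units; beyond the scatter) from compound 3 to compound 4, at least 10-fold (1.03 log units) apart, beyond the scatter of two such steps Compound 2 gives < 10 nM, which is a limit of the assay and not a number.

The compounds shown leave open how a longer chain on that oxygen, or an amine or a carboxylic acid in place of the hydroxy, would behave on either core. They also leave open whether the two cores would differ as much with those groups.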